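A few compounds are considered here, and "the series" means these few. Any claim that something is new, unique, unknown or untested is made for them only; others in the source may bear on it.

Compound 1 `O=C(O)CCC1=C(c2ccc(Cl)cc2)NC(=S)NC1c1ccccc1O` gives 14.7% in a functional assay on the whole organism (strain Albino) for inhibition, with Rattus norvegicus as the target, with stated times of 1 h and 2 h, at a dose of 20 mg/kg by the oral route (a higher number here means more inhibition at the dose given (going by the name of the read-out), a lower number less inhibition), the lowest of the three measured numbers. Compound 2 `O=C(O)CCC1=C(c2ccccc2)NC(=S)NC1c1ccccc1O` gives 28.6% in this assay, and compound 3 `COc1ccc(C2=C(CCC(=O)O)C(c3ccccc3O)NC(=S)N2)cc1` gives 27%. Every measured step changes only the chloro on the aromatic carbon: a number 13.9 percentage points higher from compound 1 to compound 2 (beyond the scatter) and a number 12.3 percentage points higher from compound 1 to compound 3 (beyond the scatter), while a number 1.6 percentage points lower from compound 2 to compound 3 (within the scatter). Compound 4 `O=C(O)CCC1=C(c2ccc(Cl)cc2)NC(=S)NC1c1ccccn1` departs from compound 1 at another place: pyridin-2-yl in place of 2-hydroxyphenyl on a saturated ring carbon. Going by the values given here, no measured step touches the 2-hydroxyphenyl, so the three measured compounds give no direction for this change, and the expectation rests on compound 1 alone with wide uncertainty. The step from compound 1 to compound 4 is estimated as a number 2.3 percentage points higher from compound 1 to compound 4 (within the scatter), none beyond the scatter. Compound 4 is therefore expected to give about 17%, within 3% to 35%.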

Compound 4, a percentage reported as inhibition, in the whole organism at one dose (the size of the read-out at that dose, not a potency): 21.8%
For compound 4 the middle estimate is 4.8 percentage points below the measured one; the range from low to high includes it.
By their numbers in this assay, from the lowest: compounds 1, 4, 3 and 2 (each within the scatter of the next, the first and the last beyond it).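

Going by these compounds alone, replacing 2-hydroxyphenyl with pyridin-2-yl, which loses the hydrogen-bond donor, gives a number 7.1 percentage points higher from compound 1 to compound 4 (within the scatter) in this assay, so with the 4-chlorophenyl group in place, this exchange on the saturated ring carbon leaves no step separable from the scatter. The hydroxyl-bearing phenyl is therefore not shown to be required at this dose, at least in this one comparison. Nothing measured bears on why the step has this size.

From the compounds shown here alone, whether pyridin-2-yl behaves alike alongside the unsubstituted phenyl of compound 2 or the methoxy-bearing ring of compound 3 remains open. So does the outcome with a plain phenyl or a 2-aminophenyl at this position.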